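A few compounds are considered here, and "the series" means these few. Any claim that something is new, unique, unknown or untested is made for them only; others in the source may bear on it.

Compound 1 `Cc1nc2c3ccccc3ccc2c2nc3c(ccc4ccccc43)c(-c3cccc([N+](=O)[O-])c3)c12`: 13200 nM
Compound 2 `Cc1nc2c3ccccc3ccc2c2nc3c(ccc4ccccc43)c(C)c12`: > 80000 nM, a limit
Compound 3 `Cc1nc2c3ccccc3ccc2c2nc3c(ccc4ccccc43)c(-c3ccccc3)c12`: > 80000 nM, a limit

In a functional assay on HCT-116 cells (Homo sapiens) for cytotoxicity, read by MTT assay, with a stated time of 48 h (on this read-out higher numbers stand for weaker inhibition and lower numbers for stronger inhibition), compound 1 gives 13200 nM. For compound 3 the value of > 80000 nM is a limit of this assay, not a number, so compound 3 stands at the weak end of what can be read, as the limit of > 80000 nM in this assay, at which 2 of the 3 values shown sit, shows. Compound 4 `Cc1nc2c3ccccc3ccc2c2nc3c(ccc4ccccc43)c(-c3ccc(O)cc3)c12` differs from compound 3 by hydroxy in place of hydrogen on an aromatic carbon. Within the data shown here, no measured step tests a hydroxy; the nearest ones are an at least 6.0-fold higher number from compound 1 to compound 3 (0.78 log units; beyond the scatter), which was at least modest, and a step that the two limits leave unreadable from compound 2 to compound 3, which cannot be sized. An only small change is therefore expected, as an at least 1.3-fold lower number from compound 3 to compound 4 (0.12 log units; that floor lies within the scatter). Compound 4 is expected at about 60000 nM, between 15000 nM and 160000 nM.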

Compound 4, half-maximal inhibitory concentration: 3190 nM
The estimate for compound 4 lay 19-fold (1.27 log units) above the measured number; the whole stated range lies above it.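

In this assay, a hydroxy para to a large group gives an at least 25-fold lower number from compound 3 to compound 4 (1.39 log units; beyond the scatter), so a single added atom on the phenyl ring at this position can move a compound out of the unreadable range. Replacing methyl with 4-hydroxyphenyl gives an at least 25-fold lower number from compound 2 to compound 4 (1.39 log units; beyond the scatter), and 4-hydroxyphenyl also outperforms 3-nitrophenyl, with a 4.1-fold lower number from compound 1 to compound 4 (0.62 log units; beyond the scatter). Compound 2 and compound 3 each stand at a limit, not a number, so the first two steps are floors: the limit of > 80000 nM in this assay, at which 2 of the 4 values shown sit.

Still open, going by these compounds, is whether a methoxy or an amine in the same place would match the hydroxy, and whether a hydroxy elsewhere on the phenyl ring would do so.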